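Removing the hydroxymethyl group from compound 2

This account rests on a few compounds, and the source may have more. Where it says the series, first, only, none or still open, it means among the compounds named here.

Among the compounds with values here, in a functional assay on A-375 cells (Homo sapiens) for cytotoxicity, read by MTT assay, with a stated time of 72 h (on this read-out lower numbers stand for stronger inhibition and higher numbers for weaker inhibition), compound 2 (`CC1(C)O[C@@H](CO)[C@H](Cn2cc(Cn3c4c(c5ccccc53)C(=O)c3c[n+]([O-])c5ccccc5c3C4=O)nn2)O1`) gives 190 nM, the higher of the two numbers so far, and compound 1 (`O=C1c2c[n+]([O-])c3ccccc3c2C(=O)c2c1c1ccccc1n2Cc1cn([C@@H]2C[C@H](O)[C@@H](CO)O2)nn1`) gives 20 nM. Compound 3 (`CC1(C)OC[C@@H](Cn2cc(Cn3c4c(c5ccccc53)C(=O)c3c[n+]([O-])c5ccccc5c3C4=O)nn2)O1`) carries 2,2-dimethyl-1,3-dioxolan-4-yl in place of 5-(hydroxymethyl)-2,2-dimethyl-1,3-dioxolan-4-yl on a saturated chain carbon bound to an aromatic nitrogen. Within the data shown here, only one measured step bears on this, and only indirectly: a 9.5-fold higher number from compound 1 to compound 2 (0.98 log units; beyond the scatter). That modest step exchanged the whole substituent on the aromatic nitrogen, so it shows that this assay responds to this substituent. Among the measured compounds shown here, no measured step isolates the loss of the hydroxymethyl group, so its size stays open. The expected change is small, perhaps slightly upward and not clearly beyond the scatter: a 1.2-fold higher number from compound 2 to compound 3 (0.06 log units; within the scatter). The estimated value for compound 3 is 220 nM, with an expected range of 70 nM to 650 nM.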

Compound 3, half-maximal inhibitory concentration: 450 nM
The estimate for compound 3 lay 2.0-fold (0.31 log units) below the measured number, within the range that was stated.
By their numbers in this assay, from the lowest: compound 1; then compound 2; then compound 3.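

Within the data shown here, the step of a 2.4-fold higher number from compound 2 to compound 3 (0.37 log units; beyond the scatter) in this assay is the first to isolate the hydroxymethyl group of 5-(hydroxymethyl)-2,2-dimethyl-1,3-dioxolan-4-yl, and it shows that this group alone moves the number beyond the scatter. The wider exchange on the aromatic nitrogen, a 23-fold higher number from compound 1 to compound 3 (1.35 log units; beyond the scatter), is a large step, so the substituent at this place carries more of the variation in this series than the earlier pair showed. Nothing available here accounts for either step.

The compounds shown leave open whether the step follows the hydroxyl or the whole hydroxymethyl group. A methyl, aminomethyl or carboxylic acid group in the same place would separate these readings, and the series as shown does not say how any of them would read out.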